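The source may hold more compounds than are shown below. What is called first, only, known or untested is meant among the compounds shown, and "the series" means these compounds.

- Compound 1 `C#Cc1cn([C@@H]2O[C@H](CO)[C@@H](O)[C@H]2O)c2ncnc(OC)c12` gives 1730 nM
- Compound 2 `CSc1ncnc2c1c(-c1ccoc1)cn2[C@@H]1O[C@H](CO)[C@@H](O)[C@H]1O` gives 5390 nM
- Compound 3 `CN(C)c1ncnc2c1c(-c1ccoc1)cn2[C@@H]1O[C@H](CO)[C@@H](O)[C@H]1O` gives 9060 nM

All three values come from a functional assay on HeLa S3 cells (Homo sapiens) for antiproliferative activity, read by XTT assay, with a stated time of 72 h (a lower number here means a stronger inhibitor, a higher number a weaker inhibitor), and nothing else. Compound 3 (9060 nM) sits within the scatter of compound 2, while compound 1 (1730 nM) shows a clearly lower number than either.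

The next compound is compound 4 `C#Cc1cn([C@@H]2O[C@H](CO)[C@@H](O)[C@H]2O)c2ncnc(N(C)C)c12`, made by one change to compound 3, with ethynyl in place of furan-3-yl on an aromatic carbon of the five-membered aromatic ring: ethynyl in place of furan-3-yl on an aromatic carbon. For the measured compounds named here, no measured step covers this swap directly. Going by the values given here, the only measured step is a 1.7-fold higher number from compound 2 to compound 3 (0.23 log units; within the scatter), with dimethylamino in place of methylsulfanyl at a different place on the molecule, and it stays within the scatter.

The better guide is compound 1 (1730 nM), which already carries ethynyl and differs from compound 4 in having methoxy where compound 4 has dimethylamino. If that exchange proves as small as the measured one, compound 4 should land near compound 1, although this rests on a single ethynyl compound. The estimated change is a 3.0-fold lower number from compound 3 to compound 4 (0.48 log units; beyond the scatter), towards a lower number in this assay. For compound 4 the expected value is 3000 nM, with an estimated range from 900 nM to 10000 nM.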

Compound 4, half-maximal inhibitory concentration: 810 nM
Compound 4: the middle estimate sits 3.7-fold (0.57 log units) above what was measured; the whole stated range lies above it.
By their numbers in this assay, from the lowest: compound 4; then compound 1; then compounds 2 and 3 (each within the scatter of the next).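

In this assay, the place on the five-membered aromatic ring, two ring bonds from the ring nitrogen, proves to be a sensitive one: putting ethynyl in place of furan-3-yl gives an 11-fold lower number from compound 3 to compound 4 (1.05 log units; beyond the scatter), the first step shown at this place and the largest step in the set. The group on the other aromatic carbon also counts once ethynyl is present, since dimethylamino in place of methoxy gives a 2.1-fold lower number from compound 1 to compound 4 (0.33 log units; beyond the scatter), a modest step but one beyond the scatter, whereas the earlier exchange of methylsulfanyl for dimethylamino in the furan-3-yl series stayed within it, at a 1.7-fold higher number from compound 2 to compound 3 (0.23 log units; within the scatter). Nothing available here explains why either change shifts the number in these cells.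

On these data alone, it remains open whether the large step reflects something ethynyl adds or something lost with furan-3-yl, and a plain hydrogen atom, a phenyl ring or a longer alkyne chain such as propynyl at this place would help separate the two. As far as these compounds go, it is also open how methylsulfanyl, or a simple primary amine, would behave on the other aromatic carbon alongside ethynyl.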